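A few compounds are considered here, and "the series" means these few. Any claim that something is new, unique, unknown or untested is made for them only; others in the source may bear on it.

So far only two compounds have been measured. In a functional assay on SK-OV-3 cells (Homo sapiens) for cytotoxicity, read by MTT assay, with a stated time of 72 h (on this read-out lower numbers stand for stronger inhibition and higher numbers for weaker inhibition), compound 1 (`COc1ccc(C(CC(=O)N[C@@H](CC(C)C)B(O)O)NC(=O)c2ccccc2)cc1`) gives 8430 nM and compound 2 (`COc1ccc([C@H](CC(=O)N[C@@H](CC(C)C)B(O)O)NC(=O)c2ccccc2)cc1`) gives 14500 nM. These two numbers are all that can place compound 2, and they cannot be told apart: the change is a 1.7-fold higher number from compound 1 to compound 2 (0.24 log units; within the scatter). The only thing separating the two compounds is the fact that one of compounds 1 and 2 is drawn with a defined configuration and the other without, at the place where they differ.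

Compound 3 (`COc1ccc([C@@H](CC(=O)N[C@@H](CC(C)C)B(O)O)NC(=O)c2ccccc2)cc1`) has the same atoms and bonds as compound 2: the two compounds have the same atoms and bonds and differ only in configuration as drawn: 1 of 2 stereo elements differ; a stereocentre at a saturated chain carbon is drawn S in compound 2 and R in compound 3. Among the compounds with values here, this is the same carbon at which compounds 1 and 2 differ, so that single measured step is the only guide. If compound 1 is a mixture of the S and R forms, which its drawing leaves open, then its 8430 nM already carries the contribution of the R form. A mixture that sits so close to the pure S form leaves little room for a large effect, so only a modest shift towards a lower number is expected. The estimated change is a 2.2-fold lower number from compound 2 to compound 3 (0.35 log units; beyond the scatter). In this assay, the estimate for compound 3 is 6500 nM, with the measurement expected between 2500 nM and 16000 nM.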

Compound 3, half-maximal inhibitory concentration: 3490 nM
For compound 3 the middle estimate is 1.9-fold (0.27 log units) above the measured one; the measured number falls inside the stated range.
By their numbers in this assay, from the lowest: compound 3; then compounds 1 and 2 (each within the scatter of the next).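

Within the data shown here, the direct comparison of the S and R forms at this saturated chain carbon gives a 4.2-fold lower number from compound 2 to compound 3 (0.62 log units; beyond the scatter) in this assay, the first step at this position that lies beyond the scatter, so the configuration drawn here does matter on this read-out, though the step is modest. The step can be tied to this carbon alone, because nothing else separates the pair: the fact that compounds 2 and 3 differ only in the configuration as drawn. The compound drawn without a configuration now also stands apart from the R form, with a 2.4-fold lower number from compound 1 to compound 3 (0.38 log units; beyond the scatter), which leaves compound 3 with the lowest number of the three, while compound 1 and compound 2 stay within the scatter of each other.

The drawing of compound 1 does not tell how much of each form it holds, so these numbers cannot show how the S and R forms add up in it. Going by these compounds, all three compounds share the same groups and the same configuration at the second stereocentre, so it remains open what the opposite configuration there would do, and whether the R form would keep its edge with an amine or a longer chain on the shared core.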